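Chain-methyl variation on the enamide of a kinase-type series

This account rests on a few compounds, and the source may have more. Where it says the series, first, only, none or still open, it means among the compounds named here.

Measured compounds:
- compound 1, `CC/C=C\C(=O)Nc1cc(Nc2ncc(C#N)c(-c3cn(C)c4ccccc34)n2)c(OC)cc1N(C)CCN(C)C`, 1360 nM in a functional assay on HepG2 cells (Homo sapiens) for antiproliferative activity, read by MTT assay, with a stated time of 72 h; on this read-out higher numbers stand for weaker inhibition and lower numbers for stronger inhibition
- compound 2, `CCC/C=C\C(=O)Nc1cc(Nc2ncc(C#N)c(-c3cn(C)c4ccccc34)n2)c(OC)cc1N(C)CCN(C)C`, 1690 nM in this assay
- compound 3, `CC/C=C\C(=O)Nc1cc(Nc2nccc(-c3cn(C)c4ccc(F)cc34)n2)c(OC)cc1N(C)CCN(C)C`, 5290 nM in this assay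

Compound 1 and compound 2 share the same core and differ only in methyl in place of hydrogen on a saturated chain carbon, two bonds along the chain from a double-bonded chain carbon. In this assay this gave a 1.2-fold higher number from compound 1 to compound 2 (0.09 log units; within the scatter), so the two values cannot be ordered. Compound 3 carries a different core; the difference between the two cores is not broken down here. Compound 3 gives the highest of the three numbers, beyond the scatter against both compound 1 and compound 2.

Compound 4, `COc1cc(N(C)CCN(C)C)c(NC(=O)/C=C\C(C)C)cc1Nc1nccc(-c2cn(C)c3ccc(F)cc23)n1`, is derived from compound 3 by methyl in place of hydrogen on a saturated chain carbon bound to a double-bonded chain carbon and a saturated chain carbon. This is the same kind of change as from compound 1 to compound 2, though the surroundings differ: there the methyl entered on a saturated chain carbon two bonds along the chain from a double-bonded chain carbon, here on a saturated chain carbon bound to a double-bonded chain carbon and a saturated chain carbon. Resting on the earlier step of a 1.2-fold higher number from compound 1 to compound 2 (0.09 log units; within the scatter), a step of about a 1.1-fold higher number from compound 3 to compound 4 (0.05 log units; within the scatter) is expected for compound 4 in this assay. The expected value for compound 4 is 6000 nM, estimated between 2800 nM and 13000 nM.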

Compound 4, half-maximal inhibitory concentration: 3920 nM
The estimate for compound 4 lay 1.5-fold (0.18 log units) above the measured number, and the stated range covers the measured number.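

In this assay the methyl on a saturated chain carbon bound to a double-bonded chain carbon and a saturated chain carbon gives a 1.3-fold lower number from compound 3 to compound 4 (0.13 log units; within the scatter), so the two values cannot be ordered. Set beside the earlier step, the change reads alike on the two cores as far as these data can tell: the same change on two cores in this assay, a 1.2-fold higher number (0.09 log units; within the scatter) from compound 1 to compound 2 and a 1.3-fold lower number (0.13 log units; within the scatter) from compound 3 to compound 4, 1.7-fold (0.22 log units) apart, within the scatter of two such steps. Among the compounds shown here, this shows only that neither step can be told from no change in these two pairs; the methyl enters at a different chain carbon in each pair, and two steps in one read-out do not establish that the change carries to other cores.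

Open, as far as these compounds go, is whether a larger group at the end of the same chain, such as a longer chain, a cyclopropyl or a dimethylamino group, would give a step beyond the scatter. Also open, from the compounds shown here alone, is how far the nitrile and the fluorine each contribute to the numbers on the two cores in this assay.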